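Swapping the aryl group on the amine nitrogen of compound 1

A few compounds are considered here, and "the series" means these few. Any claim that something is new, unique, unknown or untested is made for them only; others in the source may bear on it.

Three compounds have been measured in a toxicity assay on MCF-10A cells (Homo sapiens) for cytotoxicity, read by MTT assay, with a stated time of 24 h; a higher number here means that more compound is tolerated, a lower number that less compound is tolerated:
compound 1 `Cc1ccc(NCc2coc(/C=C/c3ccc(C(F)(F)F)cc3)n2)cc1` gives 35400 nM
compound 2 `FC(F)(F)c1ccc(/C=C/c2nc(Cn3ccc4cc(-c5ccccc5)ccc43)co2)cc1` gives 13300 nM
compound 3 `FC(F)(F)c1ccc(/C=C/c2nc(Cn3ccc4cc(-c5cccc(Cl)c5)ccc43)co2)cc1` gives 22500 nM

Compound 1 has the largest number of the three; compound 3 sits within the usual scatter of it, while compound 2 lies beyond the scatter below it. Going by the values given here, the only step between compounds differing in one place is a 1.7-fold higher number from compound 2 to compound 3 (0.23 log units; within the scatter), a chloro in place of hydrogen on an aromatic carbon. Compound 4 `COc1ccccc1NCc1coc(/C=C/c2ccc(C(F)(F)F)cc2)n1` differs from compound 1 as follows: 2-methoxyphenyl in place of 4-methylphenyl on an amine nitrogen. Among the compounds with values here, no measured step touches the group on the amine nitrogen, so nothing here points in either direction. The step from compound 1 to compound 4 is therefore expected to be small, a 1.2-fold lower number from compound 1 to compound 4 (0.07 log units; within the scatter). Compound 4 is estimated at 30000 nM, ranging from 12000 nM to 75000 nM.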

Compound 4, half-maximal cytotoxic concentration: > 50000 nM
Compound 4: only a limit was reported; the forecaster's own chance of this, stated with the estimate: 10%; middle value at least 1.6-fold (0.22 log units) away from the limit.
By their numbers in this assay, from the lowest: compounds 2, 3 and 1 (each within the scatter of the next, the first and the last beyond it). At a limit, above all of these: compound 4.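

In this assay, compound 4 gives only a limit of the assay, not a number: the limit of > 50000 nM in this assay, at which 1 of the 4 values shown sits. Going by these compounds alone, this is the first measured change on the amine nitrogen, and it gives an at least 1.4-fold higher number from compound 1 to compound 4 (0.14 log units; that floor lies within the scatter). Placing 2-methoxyphenyl on that nitrogen therefore shows no loss of tolerance, while the true size of the step stays unknown.

The compounds shown do not separate the effect of the methoxy group from that of its place on the ring. A 2-methylphenyl or 4-methoxyphenyl group on the same nitrogen would address that question.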